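This account rests on a few compounds, and the source may have more. Where it says the series, first, only, none or still open, it means among the compounds named here.

Series notes, thiourea-linked compounds on a shared core.

Compound 1 `CC(C)C[C@@H](NC(=S)Nc1ccccc1)c1nc2ccccc2[nH]1` is measured in a functional assay on HeLa cells (Homo sapiens) for cytotoxicity, read by MTT assay (on this read-out lower numbers stand for stronger inhibition and higher numbers for weaker inhibition), where compound 1 gives 12100 nM. Two further members are known. Compound 2 `CC(C)C[C@@H](NC(=S)Nc1cc(C(F)(F)F)cc(C(F)(F)F)c1)c1nc2ccccc2[nH]1` gives 10400 nM in this assay, a number within the usual scatter of that of compound 1, so the two are not told apart. Compound 3 `C[C@H](NC(=S)Nc1cc(C(F)(F)F)cc(C(F)(F)F)c1)c1nc2ccccc2[nH]1` gives 133000 nM in this assay, a number well beyond the scatter from that of compound 1. Of the three numbers compound 1 thus has the second highest, close to compound 2 and far from compound 3.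

The step now followed goes from compound 1 to compound 4 `CC(C)C[C@@H](NC(=S)NCc1ccccc1)c1nc2ccccc2[nH]1`, which has not been measured in this assay. The change is benzyl in place of phenyl on an amide-type nitrogen whose other neighbour is the thiocarbonyl carbon, the same difference read one bond further out being anilino to benzylamino. For the measured compounds named here, no measured pair shows this change, so its effect has to be estimated without a direct precedent.

The expectation is a step from compound 1 to compound 4 of a 1.3-fold higher number from compound 1 to compound 4 (0.12 log units; within the scatter), that is, no change beyond the scatter or a small loss. Compound 4 is therefore estimated at 16000 nM, with an expected range from 5000 nM to 50000 nM.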

Compound 4, half-maximal inhibitory concentration: 21200 nM
Estimate against measurement, compound 4: 1.3-fold (0.12 log units) below; the range from low to high includes it.
By their numbers in this assay, from the lowest: compounds 2, 1 and 4 (each within the scatter of the next, the first and the last beyond it); then compound 3.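

Benzyl in place of phenyl on the amide-type nitrogen gives, in this assay, a 1.8-fold higher number from compound 1 to compound 4 (0.24 log units; within the scatter) and so does not tell the two compounds apart. For the compounds shown here, this is the first reading of a change in the link between this nitrogen and the aromatic ring, as the earlier compounds offered no pair bearing on it. For this one pair, anilino and benzylamino are not distinguished on this read-out, so the ring need not stand directly on the nitrogen for the number to stay within the scatter of compound 1. Nothing available gives a reason for this result.

As far as these compounds go, whether a phenethyl group, a longer chain on the same nitrogen, stays within the scatter of compound 1 remains open, as does the outcome with a cyclohexyl group, which carries no aromatic ring. From the compounds shown here alone, the change is read only with an unsubstituted ring, so it is also open whether benzyl in place of phenyl would behave in the same way with the trifluoromethyl groups of compound 2.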